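Fluoro to chloro on the aromatic carbon: compound 4

The compounds below may be only part of what the source reports. "The series", "measured", "known", "first", "only" and "open" are said of these compounds alone.

Three compounds of the series carry numbers in a functional assay on SF-295 cells (Homo sapiens) for antiproliferative activity; on this read-out higher numbers stand for weaker inhibition of growth and lower numbers for stronger inhibition of growth. Compound 1 `Cc1cnc2nc(-c3ccc4ccccc4c3)cc(O)c2c1` gives 550 nM. Compound 3 `Cc1cc(C)c2c(O)cc(-c3ccc4ccccc4c3)nc2n1` gives 14800 nM. Going by the values given here, compound 2 `Cc1cnc2[nH]c(-c3cccc(F)c3)cc(=O)c2c1` gives 27.5 nM, the lowest of the three; its gaps to compound 1 and to compound 3 both lie beyond the scatter, so compound 2 is the most potent compound measured so far.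

Compound 4 `Cc1cnc2[nH]c(-c3cccc(Cl)c3)cc(=O)c2c1` has not been measured. It differs from compound 2 in one place: chloro in place of fluoro on an aromatic carbon. Among the compounds with values here, no pair of measured compounds differs in only one place, so no step of this kind has a number yet. The change leaves one heavy atom and brings one heavy atom in, with no ring, no hydrogen-bond donor or acceptor and no net charge on either side; such an exchange of one halogen for another is expected to give a step within the scatter, with no clear direction. Compound 4 is therefore expected to give 22 nM, within 7 nM to 70 nM. The expected step of a 1.3-fold lower number from compound 2 to compound 4 (0.10 log units; within the scatter) is small.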

Compound 4, concentration for 50% growth inhibition: 25.1 nM
Compound 4: middle estimate off by 1.1-fold (0.06 log units), on the low side, within the range that was stated.
By their numbers in this assay, from the lowest: compounds 4 and 2 (each within the scatter of the next); then compound 1; then compound 3.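

In this assay, going by these compounds alone, the exchange of fluoro for chloro on the aromatic carbon gives a 1.1-fold lower number from compound 2 to compound 4 (0.04 log units; within the scatter) and is the first single-place step available. At this place, meta to a large group, the two halogens cannot be told apart on this read-out, so the low number of compound 2 does not depend on fluoro specifically. Nothing at hand explains this outcome.

Going by these compounds, whether an amine, a methoxy group or a carboxylic acid on the same aromatic carbon would keep the number in this range remains open, since only two halogens are compared here. Within the data shown here, compound 1 and compound 3 differ from compound 2 and compound 4 in more than one place, so no steps to them can be read.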